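The compounds below may be only part of what the source reports. "The series", "measured", "known", "first", "only" and "open" are said of these compounds alone.

Among the measured compounds shown here, compound 1, `CCN1CCN(c2ccc(Nc3ncc(Cl)c(Nc4ccccc4C)n3)cc2)CC1`, is the one member of this small set with a number rather than a limit: in a functional assay on Jurkat cells (Homo sapiens) for inhibition, read by CCK-8 assay, with a stated time of 48 h (a lower number here means a stronger inhibitor of growth, a higher number a weaker inhibitor of growth), compound 1 gives 2060 nM. Compound 2, `CN1CCN(c2ccc(Nc3ncc(Cl)c(Nc4ccccc4)n3)nc2)CC1`, stands differently. In this assay compound 2 reaches only > 100000 nM, which is a limit of the assay and not a measured number. That is where compound 2 sits on the numbers shown, at the limit of > 100000 nM in this assay, at which 1 of the 2 values shown sits. Compound 3, `CCc1ccc(Nc2nc(Nc3ccc(N4CCN(C)CC4)cn3)ncc2Cl)cc1`, is not yet measured, and it differs from compound 2 in one place: ethyl in place of hydrogen on an aromatic carbon. The change keeps everything else of compound 2 as it is. For the measured compounds named here, no step between measured compounds is available to set the size of this change, and compound 1 differs from compound 2 in more than one place, so its value can only show that a number below the limit is reachable within this set. The author expects the step from compound 2 to compound 3 in this assay to be an at least 2.5-fold lower number from compound 2 to compound 3 (0.39 log units; beyond the scatter), a move toward stronger inhibition but one that may well leave compound 3 at or near the limit. The estimate for compound 3 in this assay is 40000 nM, expected to fall between 8000 nM and 200000 nM.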

Compound 3, concentration for 50% growth inhibition: 11100 nM
The estimate for compound 3 lay 3.6-fold (0.56 log units) above the measured number; low and high end bracket the measured number.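

Among the compounds shown here, the ethyl group on an aromatic carbon, para to a large group, gives an at least 9.0-fold lower number from compound 2 to compound 3 (0.95 log units; beyond the scatter) in this assay, and this is the first step in the set that can be read at all. For the compounds shown here, until this result, the only number clear of the limit belonged to compound 1, which differs from compound 2 in more than one place, so no single change could be tied to such a move. The change from phenyl to 4-ethylphenyl now shows that this one position alone is enough to bring a compound of this set off the limit, although the size of the step remains a lower bound, since compound 2 holds a limit of the assay and no number: the limit of > 100000 nM in this assay, at which 1 of the 3 values shown sits.

Going by these compounds, whether this depends on ethyl itself stays open, as a methyl, a longer chain such as propyl, a methoxy, an amine or a carboxylic acid on the same carbon would be needed to tell. Also open, on these data alone, is whether ethyl at this position would give a step of similar size on the core of compound 1.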